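The source may hold more compounds than are shown below. What is called first, only, known or untested is meant among the compounds shown, and "the series" means these compounds.

Measured compounds:
compound 1, `CN1CCN(C(=O)Cn2c(=O)c3c(ncn3C)n(C)c2=O)CC1`: 8.6%
compound 2, `Cn1cnc2c1c(=O)n(CC(=O)N1CCN(C(=O)OC(C)(C)C)CC1)c(=O)n2C`: 20%
compound 3, `C=CC(=O)N1CCN(C(=O)Cn2c(=O)c3c(ncn3C)n(C)c2=O)CC1`: 1.3%

All three share one core and differ only in the group on the amine nitrogen in the ring. In a functional assay on MGC-803 cells (Homo sapiens) for inhibition, read by MTT assay, with a stated time of 48 h, tested at 20 uM (on this read-out higher numbers stand for more inhibition at the one concentration tested (going by the name of the read-out) and lower numbers for less inhibition), compound 3 gives the lowest of the three numbers. The first of its two gaps is a number 7.3 percentage points lower from compound 1 to compound 3 (within the scatter), so those two cannot be ordered; the second is a number 18.7 percentage points lower from compound 2 to compound 3 (beyond the scatter), and compound 2 stands clear of it.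

The step to compound 4, `Cn1cnc2c1c(=O)n(CC(=O)N1CCN(C(=O)/C=C/c3ccccc3)CC1)c(=O)n2C`, is 2-phenylethenyl in place of vinyl on a carbonyl carbon. The measured changes that bear on it are the exchange on the same carbonyl carbon, a number 18.7 percentage points lower from compound 2 to compound 3 (beyond the scatter), and the exchange on the same nitrogen, a number 11.4 percentage points higher from compound 1 to compound 2 (beyond the scatter). Among the compounds with values here, both are modest, and neither brings in a six-membered aromatic ring, so there is no direct precedent for the entering group. Since every change at this position has given a modest step in this assay, as a number 18.7 percentage points lower from compound 2 to compound 3 (beyond the scatter) shows, the expected step is a number 8.7 percentage points higher from compound 3 to compound 4 (within the scatter), a small rise that may still fall within the scatter. Compound 4 is accordingly estimated at 10%, with a range from 0% to 28%.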

Compound 4, a percentage reported as inhibition, at one concentration (the size of the read-out at that concentration, not a potency): 9.5%
Beside the measured number, compound 4's estimate is 0.5 percentage points above it; the measured number falls inside the stated range.
By their numbers in this assay, from the lowest: compounds 3, 1 and 4 (each within the scatter of the next); then compound 2.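

In this assay, within the data shown here, 2-phenylethenyl in place of vinyl on a carbonyl carbon is the first exchange here that brings in a six-membered aromatic ring of carbon only, and the result (a number 8.2 percentage points higher from compound 3 to compound 4 (within the scatter)) does not separate the two groups. Compound 4 also cannot be told apart from the methyl compound (a number 0.9 percentage points higher from compound 1 to compound 4 (within the scatter)), but the tert-butoxy compound stands clear of it (a number 10.5 percentage points lower from compound 2 to compound 4 (beyond the scatter)), so among these four compounds only compound 2, with tert-butoxycarbonyl on the nitrogen, stands apart from the rest, while compound 1, compound 3 and compound 4 lie within the scatter of one another. Nothing at hand gives a reason for these numbers.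

Still open, going by these compounds, is whether the separation of compound 2 belongs to tert-butoxy alone or extends to other groups on the same carbonyl carbon, such as isopropoxy or benzyloxy. Also open, on these data alone, is whether a chloro or methoxy group on the phenyl ring of 2-phenylethenyl, or a saturated cyclohexyl ring in its place, would move the number beyond the scatter of compound 4.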